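A few compounds are considered here, and "the series" means these few. Any claim that something is new, unique, unknown or untested is made for them only; others in the source may bear on it.

Measured compounds so far:
compound 1 `COc1ccc(C)cc1NC(=S)N/N=C/c1ccc2ccccc2n1` — > 100000 nM
compound 2 `S=C(N/N=C/c1ccc2ccccc2n1)Nc1cccc(Cl)c1` — 61300 nM

Notes on the series. In a functional assay on SGC-7901 cells (Homo sapiens) for antiproliferative activity, read by sulforhodamine B assay, with a stated time of 72 h (a lower number here means a stronger inhibitor, a higher number a weaker inhibitor), compound 2 gives 61300 nM. Compound 1 gives > 100000 nM in this assay, which is a limit of the assay and not a number. Among the compounds with values here, compound 2 therefore stands as the only compound with an actual value here, and the other value shown sits at the limit (the limit of > 100000 nM in this assay, at which 1 of the 2 values shown sits), so the whole series as measured is weak.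

Compound 3 `COc1ccc(NC(=S)N/N=C/c2ccc3ccccc3n2)cc1` is the next compound and has not been measured in this assay. It differs from compound 2 in one place: 4-methoxyphenyl in place of 3-chlorophenyl on an amide-type nitrogen. Within the data shown here, no step between measured compounds is available to calibrate this change. Among the measured compounds shown here, with compound 2 already weak and the one other compound at the limit (the limit of > 100000 nM in this assay, at which 1 of the 2 values shown sits), the expectation for the step is a modest move toward weaker inhibition, possibly not beyond the scatter, with a real chance that only a limit is reported. The estimated step from compound 2 to compound 3 is a 1.6-fold higher number from compound 2 to compound 3 (0.21 log units; within the scatter). Compound 3 is expected to give about 100000 nM in this assay, within a range of 35000 nM to 300000 nM.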

Compound 3, half-maximal inhibitory concentration: 89600 nM
Estimate against measurement, compound 3: 1.1-fold (0.05 log units) above; low and high end bracket the measured number.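

In this assay, putting 4-methoxyphenyl in place of 3-chlorophenyl on the amide-type nitrogen, whose other neighbour is the thiocarbonyl carbon, gives a 1.5-fold higher number from compound 2 to compound 3 (0.16 log units; within the scatter). Within the data shown here, this is the first step that can be read between two actual numbers, and it shows that this position tolerates the exchange of a chlorine-bearing ring for a methoxy-bearing one, including the hydrogen-bond acceptor counted on 4-methoxyphenyl, with no change that can be told from the scatter. Compound 1 remains a limit of the assay and not a number, so the series as shown stays weak and close to that limit: the limit of > 100000 nM in this assay, at which 1 of the 3 values shown sits.

Left open is whether a different substituent on this ring, such as a carboxylic acid or a dimethylamino group, or a longer alkyl chain in place of the aryl group on this nitrogen, would give a number clearly apart from those of compound 2 and compound 3. Also open, on these data alone, is what the substituent and its ring position each contribute, as this single step changes both together on the shared core.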